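The source may hold more compounds than are shown below. What is called first, only, known or untested is meant among the compounds shown, and "the series" means these compounds.

Values in a functional assay on PC-3 cells (Homo sapiens) for inhibition, read by MTT assay, with a stated time of 72 h; on this read-out lower numbers stand for stronger inhibition and higher numbers for weaker inhibition:

compound 2 `Cc1ccc(Cn2cc(CSC(=S)N3CCN(C(=O)OC(C)(C)C)CC3)nn2)cc1`: 17300 nM
compound 1 `COc1ccc(-n2cc(CSC(=S)N3CCN(C(=O)OC(C)(C)C)CC3)nn2)cc1`: > 128000 nM, a limit of this assay
compound 3 `Cc1ccc(Cn2cc(CSC(=S)N3CCN(C(=O)OCc4ccccc4)CC3)nn2)cc1`: > 128000 nM, a limit of this assay

Going by the values given here, compound 2 holds the only number in this assay; the other two entries are limits. The step from compound 1 to compound 2, an at least 7.3-fold lower number from compound 1 to compound 2 (0.86 log units; beyond the scatter), and the step from compound 2 to compound 3, an at least 7.3-fold higher number from compound 2 to compound 3 (0.86 log units; beyond the scatter), both reach the same point, (the limit of > 128000 nM in this assay, at which 2 of the 3 values shown sit), so neither can be sized fully.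

Compound 4 `COc1ccc(Cn2cc(CSC(=S)N3CCN(C(=O)OC(C)(C)C)CC3)nn2)cc1` has not been measured. It differs from compound 2 by methoxy in place of methyl on an aromatic carbon. Among the compounds with values here, of the measured steps, only the one from compound 1 to compound 2 touches the methoxy group, and there it is combined with the change from phenyl to benzyl on the aromatic nitrogen, so its weight for compound 4 is uncertain; the step from compound 2 to compound 3 concerns the carbamate and does not bear on it. A step in this assay of a 2.0-fold higher number from compound 2 to compound 4 (0.31 log units; beyond the scatter) toward a higher number is expected, with a fair chance of a limit. For compound 4 a value of 35000 nM is estimated, between 10000 nM and 128000 nM.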

Compound 4, half-maximal inhibitory concentration: > 128000 nM
Compound 4: no number, only a limit (the forecaster's own chance of this, stated with the estimate: 30%); at least 3.6-fold (0.56 log units) between middle value and limit.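

In this assay, the change from 4-methylbenzyl to 4-methoxybenzyl gives an at least 7.3-fold higher number from compound 2 to compound 4 (0.86 log units; beyond the scatter), and methoxy in place of methyl is the only difference, so this group is now seen apart from the phenyl to benzyl change that accompanied it in compound 1. Compound 4 gives > 128000 nM, which is a limit and not a number. Among the 4-substituted benzyl compounds shown, only the methyl of compound 2 keeps a number, so the read-out of this position rests on a single measured value: the limit of > 128000 nM in this assay, at which 3 of the 4 values shown sit.

The step between compound 1 and compound 4 cannot be read, as both ends are limits. Going by these compounds, whether a chlorine, an amine, a carboxylic acid or a longer chain in this place on the benzyl ring would give a number remains open.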